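A few compounds are considered here, and "the series" means these few. Any claim that something is new, unique, unknown or untested is made for them only; others in the source may bear on it.

The measured compounds:
Compound 1 `O=C(Nc1ccc(Cl)cc1)Nc1ccc(Nc2ncnc3c2OCCN3)cc1` gives > 10000 nM in an assay on isolated protein for inhibition of proto-oncogene tyrosine-protein kinase receptor Ret variant V804L (Homo sapiens), read by 33P incorporation, with stated times of 15 min and 40 min (on this read-out lower numbers stand for stronger inhibition and higher numbers for weaker inhibition), which is a limit of the assay and not a number.
Compound 2 `O=C(Nc1ccc(Nc2ncnc3c2OCCN3)cc1)Nc1ccc(C(F)(F)F)cc1` gives 2470 nM in this assay.
Compound 3 `Cc1ccc(F)c(NC(=O)Nc2ccc(Nc3ncnc4c3OCCN4)cc2)c1` gives 7000 nM in this assay.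

Compound 1 therefore sits at the limit of > 10000 nM in this assay, at which 1 of the 3 values shown sits, so only a floor is known for it and any step away from it can only be given as a least value. Compound 4 `CC(C)(C)c1cc(NC(=O)Nc2ccc(Nc3ncnc4c3OCCN4)cc2)no1` differs from compound 1 in one place (5-(tert-butyl)-1,2-oxazol-3-yl in place of 4-chlorophenyl on an amide-type nitrogen).

Two measured steps start from compound 1 and swap the same aryl group on the urea nitrogen: an at least 4.0-fold lower number from compound 1 to compound 2 (0.60 log units; beyond the scatter) and an at least 1.4-fold lower number from compound 1 to compound 3 (0.15 log units; that floor lies within the scatter). Both lead to lower numbers, one of them beyond the scatter. Between the two replacements there is a 2.8-fold higher number from compound 2 to compound 3 (0.45 log units; beyond the scatter). Going by the values given here, no measured step brings in a five-membered ring with hetero atoms, so the size of the move for compound 4 rests on the pattern that leaving the 4-chlorophenyl has so far lowered the number. A step of the kind seen with compound 2 is expected, an at least 5.0-fold lower number from compound 1 to compound 4 (0.69 log units; beyond the scatter), that is toward stronger inhibition. Compound 4 is accordingly estimated at 2000 nM, within 400 nM to 10000 nM.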

Compound 4, half-maximal inhibitory concentration: 58 nM
Beside the measured number, compound 4's estimate is 34-fold (1.54 log units) above it, and the stated range ends above it.
By their numbers in this assay, from the lowest: compound 4; then compound 2; then compound 3. At a limit, above all of these: compound 1.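

The earlier compounds shown here varied only the substituted phenyl group on the amide-type nitrogen, and those changes moved the number modestly. Putting 5-(tert-butyl)-1,2-oxazol-3-yl at this place gives a 43-fold lower number from compound 2 to compound 4 (1.63 log units; beyond the scatter) and a 120-fold lower number from compound 3 to compound 4 (2.08 log units; beyond the scatter) in this assay, so the choice of group here can matter far more than the phenyl series alone suggested. The step from the chlorinated compound is an at least 170-fold lower number from compound 1 to compound 4 (2.23 log units; beyond the scatter), which gives only a least size, since compound 1 stands at a limit of the assay and not at a number: the limit of > 10000 nM in this assay, at which 1 of the 4 values shown sits.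

This change replaces the ring and its substituent together, so the compounds shown cannot say whether the five-membered ring with its two hetero atoms or the tert-butyl group accounts for the large drop. A phenyl ring carrying tert-butyl, or the same 1,2-oxazol-3-yl ring carrying methyl in place of tert-butyl, would separate these two parts, and neither is among the compounds shown.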